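Replacing 4-methoxyphenyl with hydrogen in compound 1

The source may hold more compounds than are shown below. What is called first, only, known or untested is meant among the compounds shown, and "the series" means these compounds.

Measured in a functional assay on MCF7 cells (Homo sapiens) for antiproliferative activity, read by MTT assay, with a stated time of 72 h; a higher number here means a weaker inhibitor, a lower number a stronger inhibitor:
- compound 1 `COc1ccc(N2C(=O)COc3ccc(-c4ccc(O)cc4)cc32)cc1`: 17300 nM
- compound 2 `CC(C)N1C(=O)COc2ccc(-c3cccc(NS(=O)(=O)c4ccc(F)cc4)c3)cc21`: 26000 nM

Compound 1 stands at 17300 nM and compound 2 at 26000 nM. Going by the values given here, these two values lie within the scatter of each other, so neither compound can be ranked ahead of the other, and compound 1 has no separation from its only measured neighbour.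

The next compound is compound 3 `O=C1COc2ccc(-c3ccc(O)cc3)cc2N1`, which keeps the core of compound 1. The change is hydrogen in place of 4-methoxyphenyl on an amide-type nitrogen in a ring. Among the compounds with values here, no measured pair isolates this change, so the series offers no direct precedent for its size.

In this assay, a moderate step towards a higher number is expected, although a result within the scatter of compound 1 at 17300 nM would remain plausible. The estimated change is a 1.7-fold higher number from compound 1 to compound 3 (0.24 log units; within the scatter). The estimate for compound 3 is 30000 nM, with the value expected between 10000 nM and 90000 nM.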

Compound 3, half-maximal inhibitory concentration: > 40000 nM
Compound 3: a limit, no number; the forecaster's own chance of this, stated with the estimate: 25%; middle value at least 1.3-fold (0.12 log units) away from the limit.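

In this assay, compound 3 reads > 40000 nM, which is a limit of the assay and not a number. Hydrogen in place of 4-methoxyphenyl on the amide-type nitrogen in a ring gives an at least 2.3-fold higher number from compound 1 to compound 3 (0.36 log units; beyond the scatter), so this position now has a direct comparison, and its first step lies beyond the scatter, with the 4-methoxyphenyl form as the stronger of the pair. The step gives only a minimum size, and its upper end remains undefined: the limit of > 40000 nM in this assay, at which 1 of the 3 values shown sits.

Compound 2 differs from compound 1 and compound 3 in more than one place, so it does not show how much of this step belongs to the nitrogen group alone. Open, as far as these compounds go, is whether a small group such as methyl, a longer chain such as n-butyl or an unsubstituted phenyl on this nitrogen would stay near compound 1 at 17300 nM or fall towards compound 3, which would separate the contribution of the aromatic ring from that of the methoxy group.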